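Adding a fluorine where the unbound fraction already sits low

A few compounds are considered here, and "the series" means these few. Any claim that something is new, unique, unknown or untested is made for them only; others in the source may bear on it.

The three measured compounds share a core in which a substituted piperidine carries a methoxyphenyl group. Compound 2 is `COc1ccccc1C1CCN(c2ccn3c(CC4CC4)nnc3c2Cl)CC1`. In an ADME assay on a cell-free system (plasma, Rattus norvegicus) for protein binding (on this read-out higher numbers stand for a larger free fraction and lower numbers for a smaller free fraction), compound 2 gives < 0.01, which is a limit of the assay and not a number. Compound 3, `COc1cccc(F)c1C1CCN(c2ccn3c(CC4CC4)nnc3c2Cl)CC1`, gives < 0.01 in this assay, again a limit rather than a number. Compound 1, `COc1c(F)cccc1C1CCN(c2ccn3c(CC(F)(F)F)nnc3c2C#N)CC1`, which has a different core, gives 0.04 in this assay.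

The step from compound 2 to compound 3, fluoro in place of hydrogen on an aromatic carbon, is a step that the two limits leave unreadable from compound 2 to compound 3, so it tells nothing about its size. Compound 4 is `COc1c(F)cccc1C1CCN(c2ccn3c(CC4CC4)nnc3c2Cl)CC1`. It differs from compound 2 by fluoro in place of hydrogen on an aromatic carbon. Among the measured compounds shown here, only the step from compound 2 to compound 3 bears on this change, and because the limit of < 0.01 in this assay, at which 2 of the 3 values shown sit, its size cannot be read. For the measured compounds named here, no measured step therefore supports a step beyond the scatter in this assay in either direction.

Compound 4 is expected to give 0.008, between 0.003 and 0.02. This estimate means a step that the limit leaves unreadable from compound 2 to compound 4, expected to stay within the scatter, with a good chance that the assay again reports only a limit.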

Compound 4, unbound fraction: < 0.01
Compound 4 was reported as a limit (the forecaster's own chance of this, stated with the estimate: 65%); the middle value is on the limit's open side.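

No step among compound 2, compound 3 and compound 4 can be read, because all three stop at the same point: the limit of < 0.01 in this assay, at which 3 of the 4 values shown sit.

The compounds shown leave open how large the free fraction of these three compounds really is, and whether adding a fluoro to the 2-methoxyphenyl group changes it at all.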